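Shortening the Ester Chain in a Prodrug Series

The source may report more compounds than this note shows. Statements on the series, on what has been measured and on what is new or still open speak of the compounds shown alone.

Measured so far:
compound 1 `CC1(COS(=O)(=O)ON2C(=O)N3C[C@H]2CC[C@H]3C(N)=O)CCOC1=O` gives 52%
compound 2 `Cc1ccccc1OC(=O)OCCC(C)(C)COS(=O)(=O)ON1C(=O)N2C[C@H]1CC[C@H]2C(N)=O` gives 46%
compound 3 `CCCCCCCOC(=O)C(C)(C)COS(=O)(=O)ON1C(=O)N2C[C@H]1CC[C@H]2C(N)=O` gives 60%

In an ADME assay on the whole organism for pharmacokinetics, with Cynomolgus monkey (Macaca fascicularis) as the target, read by LC-MS, with a stated time of 24 h, at a dose of 20 mg/kg by the oral route (on this read-out higher numbers stand for higher oral bioavailability and lower numbers for lower oral bioavailability), compound 3 and compound 1 cannot be told apart within the usual scatter, while compound 2 sits beyond the scatter below compound 3. Compound 4 `CCOC(=O)C(C)(C)COS(=O)(=O)ON1C(=O)N2C[C@H]1CC[C@H]2C(N)=O` differs from compound 3 in one place: hydrogen in place of pentyl on a saturated chain carbon, two bonds along the chain from an oxygen next to a carbonyl group. For the measured compounds named here, no measured pair shows this kind of change, so the only guide is that three different ester or carbonate tails give numbers in a narrow band. The expectation is therefore no step beyond the scatter in this assay from compound 3 to compound 4, and the expected step is a number 8 percentage points lower from compound 3 to compound 4 (within the scatter). Compound 4 is estimated at 52%, within 35% to 68%.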

Compound 4, oral bioavailability: 80%
Beside the measured number, compound 4's estimate is 28 percentage points below it; measured number outside the range, above it.
By their numbers in this assay, from the lowest: compounds 2, 1 and 3 (each within the scatter of the next, the first and the last beyond it); then compound 4.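

Shortening the ester tail from heptyloxy to ethoxy gives a number 20 percentage points higher from compound 3 to compound 4 (beyond the scatter) in this assay, so at this position the length of the chain can matter, which the earlier compounds, with their differing tails, did not show. Putting 1-(ethoxycarbonyl)-1-methylethyl in place of 3-methyl-2-oxooxolan-3-yl gives a number 28 percentage points higher from compound 1 to compound 4 (beyond the scatter). Nothing at hand explains either step.

On these data alone, with only ethyl and heptyl esters to compare, the course of the change between them stays open, including what a butyl ester would give. So does the outcome for a methyl ester or a carboxylic acid at this end.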